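The compounds below may be only part of what the source reports. "The series", "measured", "known", "first", "only" and "open" are said of these compounds alone.

Measured so far:
compound 1 `CC1(C)[C@H](CNc2ccc(F)cc2C(F)(F)F)[C@H]1c1ccc(S(N)(=O)=O)cc1` with -18%
compound 2 `CC1(C)[C@@H](CNc2ccc(F)cc2OC(F)F)[C@@H]1c1ccc(S(N)(=O)=O)cc1` with 46%

In a functional assay on the whole organism with Mus musculus as the target, with stated times of 60 min and 30 min, at a dose of 1 mg/kg by the oral route (a higher number here means more inhibition at the dose given (going by the name of the read-out), a lower number less inhibition), compound 2 gives 46%, the higher of the two numbers; compound 1 gives -18%, a gap that lies beyond the usual scatter. Compound 3 `CC1(C)[C@H](CNc2ccc(F)cc2OC(F)F)[C@H]1c1ccc(S(N)(=O)=O)cc1` is not yet measured. It differs from compound 2 in this way: the two compounds have the same atoms and bonds and differ only in configuration as drawn: 2 of 2 stereo elements differ (all stereocentres are inverted: mirror images); a stereocentre at a saturated ring carbon is drawn S in compound 2 and R in compound 3; a stereocentre at a saturated ring carbon is drawn S in compound 2 and R in compound 3. Going by the values given here, no pair of measured compounds shows a step of this kind, so its size is not known from the data. Mirror-image pairs often differ strongly, and the configuration drawn for compound 3 is that drawn for compound 1, which gives -18%. Compound 3 is therefore expected to fall, with an estimated step of a number 36 percentage points lower from compound 2 to compound 3 (beyond the scatter), to about 10%, within a range from -20% to 40%.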

Compound 3, a percentage reported as inhibition, in the whole organism at one dose (the size of the read-out at that dose, not a potency): 28%
For compound 3 the middle estimate is 18 percentage points below the measured one; measured number inside the range.
By their numbers in this assay, from the lowest: compound 1; then compound 3; then compound 2.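

In this assay inverting both stereocentres gives a number 18 percentage points lower from compound 2 to compound 3 (beyond the scatter) and is a modest step, so compound 3 keeps a positive read-out in the configuration drawn for compound 1. This step can be assigned to configuration alone: the fact that compounds 2 and 3 differ only in the configuration as drawn. Within that same configuration, difluoromethoxy in place of trifluoromethyl gives a number 46 percentage points higher from compound 1 to compound 3 (beyond the scatter) and is the large step, so the aromatic substituent also matters at this position. The compounds shown leave open how a methoxy group or a nitrile would read out on that aromatic carbon, and whether trifluoromethyl gives a similar result in the configuration of compound 2.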